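A few compounds are considered here, and "the series" means these few. Any claim that something is new, unique, unknown or untested is made for them only; others in the source may bear on it.

Measured so far in a functional assay on HL-60 cells (Homo sapiens) for antiproliferative activity, read by MTT assay, with a stated time of 72 h; a higher number here means a weaker inhibitor, a lower number a stronger inhibitor:
- compound 1 `NC1=NC2(CCOCC2)N(OCCCOc2cccc(Cl)c2Cl)C(N)=N1` gives 440 nM
- compound 2 `NC1=NC2(CCSCC2)N(OCCCOc2cccc(Cl)c2Cl)C(N)=N1` gives 30 nM
- compound 3 `NC1=NC2(CCSCC2)N(OCCCOc2ccccc2Br)C(N)=N1` gives 180 nM

Of these three compounds, compound 1 has the highest number in this assay, so it is the weakest inhibitor here. Its value lies clearly above those of both other compounds, and the gap is larger to compound 2 than to compound 3.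

Compound 4 `NC1=NC2(CCOCC2)N(OCCCOc2cccc(Br)c2)C(N)=N1` keeps the core of compound 1 and changes only the aryl group. The change is 3-bromophenyl in place of 2,3-dichlorophenyl on an oxygen on a saturated carbon, with 3-bromophenyl in place of 2,3-dichlorophenyl on an oxygen on a saturated carbon.

Among the measured compounds shown here, the one measured step that bears on this is a 6.0-fold higher number from compound 2 to compound 3 (0.78 log units; beyond the scatter), a modest step beyond the scatter with 2-bromophenyl in place of 2,3-dichlorophenyl. It is only a partial guide, since it was measured on a different core and the entering group is 2-bromophenyl rather than 3-bromophenyl. For the measured compounds named here, no measured compound carries 3-bromophenyl.

A rise in the number is therefore expected, though probably a smaller one and with wide uncertainty. The expected step is a 3.0-fold higher number from compound 1 to compound 4 (0.47 log units; beyond the scatter). For compound 4 the estimated value is 1300 nM, with an expected range of 350 nM to 5000 nM.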

Compound 4, half-maximal inhibitory concentration: 560 nM
Estimate against measurement, compound 4: 2.3-fold (0.37 log units) above; low and high end bracket the measured number.
By their numbers in this assay, from the lowest: compound 2; then compound 3; then compounds 1 and 4 (each within the scatter of the next).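

In this assay, the exchange of 2,3-dichlorophenyl for 3-bromophenyl on the core of compound 1 gives a 1.3-fold higher number from compound 1 to compound 4 (0.10 log units; within the scatter) and so leaves the number unresolved from that of compound 1. Among the compounds shown here, this is the first sign that the aryl group on this oxygen can be changed without a readable shift, at least on this core and for this pair of groups. For the compounds shown here, the one earlier aryl exchange, a 6.0-fold higher number from compound 2 to compound 3 (0.78 log units; beyond the scatter) on the other core, lay beyond the scatter, but that step differs in both the core and the entering group, so the two steps cannot show which of these matters. No measurement shown gives a reason for either step.

The compounds shown leave open how 3-bromophenyl would read on the core of compound 2, and how 2-bromophenyl would read on the core of compound 1, either of which would separate the effect of the group from that of the core. They also leave open whether an unsubstituted phenyl, a 3-chlorophenyl, or a longer chain in place of the present one would hold the number on either core.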